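The compounds below may be only part of what the source reports. "The series", "measured", "known", "first", "only" and "open" are said of these compounds alone.

Compounds measured so far in a functional assay on MCF7 cells (Homo sapiens) for antiproliferative activity, read by MTT assay, with a stated time of 48 h; a lower number here means a stronger inhibitor, a higher number a weaker inhibitor:
- compound 1 `O=C(/C=C/c1cccc(NC(=O)c2ccccc2Cl)c1)c1nc2ccccc2[nH]1` gives 4570 nM
- compound 2 `O=C(Nc1cccc(/C=C/C(=O)c2nc3ccccc3[nH]2)c1)c1ccc(Br)cc1` gives 7000 nM
- compound 3 `Cc1cccc(C(=O)Nc2cccc(/C=C/C(=O)c3nc4ccccc4[nH]3)c2)c1` gives 5590 nM

Compound 3 stands second highest of the three numbers; its nearest neighbour is compound 1, at a 1.2-fold higher number from compound 1 to compound 3 (0.09 log units; within the scatter), and its furthest is compound 2, at a 1.3-fold lower number from compound 2 to compound 3 (0.10 log units; within the scatter). All three numbers sit within the scatter of one another.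

Compound 4 `Cc1cc(C)cc(C(=O)Nc2cccc(/C=C/C(=O)c3nc4ccccc4[nH]3)c2)c1` differs from compound 3 by methyl in place of hydrogen on an aromatic carbon. Within the data shown here, the steps that bear on it are the three exchanges of the aryl group on the carbonyl: a 1.5-fold higher number from compound 1 to compound 2 (0.19 log units; within the scatter), a 1.2-fold higher number from compound 1 to compound 3 (0.09 log units; within the scatter) and a 1.3-fold lower number from compound 2 to compound 3 (0.10 log units; within the scatter), none beyond the scatter. A second methyl on the same ring is therefore expected to give no step beyond the scatter in this assay, that is a 1.0-fold lower number from compound 3 to compound 4 (0.01 log units; within the scatter). Compound 4 is estimated at 5500 nM, within 2500 nM to 12000 nM.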

Compound 4, half-maximal inhibitory concentration: 24600 nM
Beside the measured number, compound 4's estimate is 4.5-fold (0.65 log units) below it, outside the stated range (above it).
By their numbers in this assay, from the lowest: compounds 1, 3 and 2 (each within the scatter of the next); then compound 4.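

In this assay, among these compounds, 3,5-dimethylphenyl is the first aryl group on the carbonyl to shift the number beyond the scatter. Methyl in place of hydrogen on an aromatic carbon gives a 4.4-fold higher number from compound 3 to compound 4 (0.64 log units; beyond the scatter), and the exchanges of the other aryl groups give a 3.5-fold higher number from compound 2 to compound 4 (0.55 log units; beyond the scatter) and a 5.4-fold higher number from compound 1 to compound 4 (0.73 log units; beyond the scatter). The three earlier aryl groups stay within the scatter of one another, so this ring is not indifferent to substitution: one added methyl weakens the series here. Nothing available bears on the reason for this step.

Still open, from the compounds shown here alone, is whether this loss is specific to methyl or also follows from a chlorine or a methoxy group on the same aromatic carbon.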